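Predicting a Fourth Antiproliferative Compound from Three Measurements

The compounds below may be only part of what the source reports. "The series", "measured", "known", "first", "only" and "open" are said of these compounds alone.

Compound 1, `Cc1ccc(/C=C/C(=O)Nc2nnc(-c3ccc(Cl)cc3)s2)cc1`: 1.25 ug/mL
Compound 2, `COc1ccc(-c2nnc(NC(=O)/C=C/c3ccc(C)cc3)s2)cc1`: 0.58 ug/mL
Compound 3, `O=C(/C=C/c1ccc(C(F)(F)F)cc1)Nc1nnc(-c2ccc(Cl)cc2)s1`: 3.09 ug/mL

All three were tested in a functional assay on A549 cells (Homo sapiens) for antiproliferative activity, read by MTT assay, with a stated time of 48 h; on this read-out lower numbers stand for stronger inhibition and higher numbers for weaker inhibition. Compound 2 gives the lowest number of the three and compound 3 the highest. Compound 3 differs from compound 1 in its core by trifluoromethyl in place of methyl on an aromatic carbon, and that difference produced a 2.5-fold higher number from compound 1 to compound 3 (0.39 log units; beyond the scatter). The change from compound 1 to compound 2 is methoxy in place of chloro on an aromatic carbon, and it produced a 2.2-fold lower number from compound 1 to compound 2 (0.33 log units; beyond the scatter).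

Compound 4, `COc1ccc(-c2nnc(NC(=O)/C=C/c3ccc(C(F)(F)F)cc3)s2)cc1`, has not yet been measured. It differs from compound 3 by methoxy in place of chloro on an aromatic carbon, the same change that turns compound 1 into compound 2, now made on the core of compound 3 rather than the core of compound 1; the place is described in the same words both times. Going by the values given here, the step from compound 3 to compound 4 in this assay is expected to be a 2.2-fold lower number from compound 3 to compound 4 (0.34 log units; beyond the scatter), set beside the earlier step because a 2.2-fold lower number from compound 1 to compound 2 (0.33 log units; beyond the scatter) is the only measured instance of this change. Since that transfer rests on a single pair and a different core, the range is kept wide. Compound 4 is expected to give 1.4 ug/mL in this assay, estimated to fall between 0.7 ug/mL and 3 ug/mL.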

Compound 4, half-maximal inhibitory concentration: 0.69 ug/mL
Compound 4: the middle estimate sits 2.0-fold (0.31 log units) above what was measured, and the stated range ends above it.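

In this assay, the change from 4-chlorophenyl to 4-methoxyphenyl pointed the same way on the core of compound 3 as on the core of compound 1, giving a 4.5-fold lower number from compound 3 to compound 4 (0.65 log units; beyond the scatter), and the two steps do not differ in size beyond the scatter: the same change on two cores in this assay, a 2.2-fold lower number (0.33 log units; beyond the scatter) from compound 1 to compound 2 and a 4.5-fold lower number (0.65 log units; beyond the scatter) from compound 3 to compound 4, 2.1-fold (0.32 log units) apart, within the scatter of two such steps. Trifluoromethyl in place of methyl gave a 1.2-fold higher number from compound 2 to compound 4 (0.08 log units; within the scatter), a step within the scatter, yet this too cannot be told apart from the step on the other core: the same change on two cores in this assay, a 2.5-fold higher number (0.39 log units; beyond the scatter) from compound 1 to compound 3 and a 1.2-fold higher number (0.08 log units; within the scatter) from compound 2 to compound 4, 2.1-fold (0.32 log units) apart, within the scatter of two such steps. The four compounds thus show that both changes carried over within this small set, but with one pair per core they cannot show whether the steps truly match or how either change would behave on any further core.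

The compounds shown leave open whether an ethoxy group or an amine in place of the methoxy would give a similar step. They also leave open how a carboxylic acid in place of the trifluoromethyl would read.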